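Replacing methylpiperazinyl with chloro in the cytotoxicity test

A few compounds are considered here, and "the series" means these few. Any claim that something is new, unique, unknown or untested is made for them only; others in the source may bear on it.

Measured in an ADME assay on Vero cells (Chlorocebus sabaeus) for cytotoxicity, read by MTT assay, with a stated time of 72 h; on this read-out higher numbers stand for lower toxicity in this test and lower numbers for higher toxicity in this test:
compound 1 `COc1ccc(-c2cc(-c3ccc(C4NC(=O)c5ccccc5N4)cc3)nc(N)n2)cc1`: 124000 nM
compound 2 `COc1cccc(-c2cc(-c3ccc(C4NC(=O)c5ccccc5N4)cc3)nc(N)n2)c1OC`: > 400000 nM
compound 3 `CN1CCN(c2ccc(-c3cc(-c4ccc(C5NC(=O)c6ccccc6N5)cc4)nc(N)n3)cc2)CC1`: 8320 nM

Compound 2 gives > 400000 nM, which is a limit of the assay and not a number. Within the data shown here, of the two exact numbers in this assay, compound 3 has the lower at 8320 nM, and the only other is compound 1 at 124000 nM.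

Compound 4 `Nc1nc(-c2ccc(Cl)cc2)cc(-c2ccc(C3NC(=O)c4ccccc4N3)cc2)n1` carries chloro in place of 4-methylpiperazin-1-yl on an aromatic carbon. The step that bears most directly on this change is a 15-fold lower number from compound 1 to compound 3 (1.17 log units; beyond the scatter), a large one in which 4-methylpiperazin-1-yl took the place of methoxy. Compound 4 loses that group again, so the large drop seen with compound 3 should largely reverse. The other measured step, an at least 3.2-fold higher number from compound 1 to compound 2 (0.50 log units; beyond the scatter), involves no 4-methylpiperazin-1-yl and also ends at a high reading. Among the measured compounds shown here, no measured step brings in chloro, so the size remains uncertain. The expected change is a large rise, a 12-fold higher number from compound 3 to compound 4 (1.08 log units; beyond the scatter). For compound 4 the estimated value is 100000 nM, with an expected range from 30000 nM to 350000 nM.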

Compound 4, half-maximal cytotoxic concentration: 323000 nM
Compound 4: middle estimate off by 3.2-fold (0.51 log units), on the low side; the measured number falls inside the stated range.
By their numbers in this assay, from the lowest: compound 3; then compound 1; then compound 4. At a limit, above all of these: compound 2.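

In this assay, chloro in place of 4-methylpiperazin-1-yl brings a large step, a 39-fold higher number from compound 3 to compound 4 (1.59 log units; beyond the scatter), so the low number of compound 3 does not persist once that group is gone from this aromatic carbon. Chloro also differs from methoxy at the same carbon, with a 2.6-fold higher number from compound 1 to compound 4 (0.42 log units; beyond the scatter), so the rise does not merely return to the level of compound 1 but goes modestly past it. 4-Chlorophenyl in place of 2,3-dimethoxyphenyl gives an at least 1.2-fold lower number from compound 2 to compound 4 (0.09 log units; that floor lies within the scatter), a floor that lies within the scatter, and this comparison cannot be read further, because one end of it is a limit and not a number: the limit of > 400000 nM in this assay, at which 1 of the 4 values shown sits.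

From the compounds shown here alone, whether the low number goes with the whole 4-methylpiperazin-1-yl group or only with its amine nitrogens stays open, and a morpholine ring or an open-chain amine on this carbon would bear on that. Going by these compounds, it is also open whether fluoro or bromo would read like chloro here.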